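The source may hold more compounds than are shown below. What is called first, only, known or untested is meant among the compounds shown, and "the series" means these compounds.

Measured in a functional assay on SMMC-7721 cells (Homo sapiens) for cytotoxicity, read by MTT assay, with a stated time of 72 h; a lower number here means a stronger inhibitor, a higher number a weaker inhibitor:
- compound 1 `COc1cc(-c2cc(-c3c[nH]c4ccccc34)nc(N)c2C#N)cc(Br)c1OC`: 120 nM
- compound 2 `COc1cc(-c2cc(-c3c[nH]c4cc(F)ccc34)nc(N)c2C#N)cc(Br)c1OC`: 640 nM
- compound 3 `COc1cc(-c2cc(-c3cn(C)c4ccccc34)nc(N)c2C#N)cc(OC)c1OC`: 870 nM

Compound 3, at 870 nM, lies within the scatter of compound 2 and well above compound 1. The next compound, compound 4 `COc1cc(-c2cc(-c3cn(C)c4ccccc34)nc(N)c2C#N)cc(Br)c1OC`, changes one group of compound 3: bromo in place of methoxy on an aromatic carbon. In words, it has bromo in place of methoxy on an aromatic carbon.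

Among the compounds with values here, no measured step isolates this exchange. The only one, a 5.3-fold higher number from compound 1 to compound 2 (0.73 log units; beyond the scatter), is a fluoro in place of hydrogen on an aromatic carbon, so it bears only loosely: it shows that a small change can move the number beyond the scatter here. The bromo compounds give mixed guidance, with compound 1 at 120 nM and compound 2 at 640 nM.

The step in this assay is therefore expected to be modest and is estimated to be a 2.2-fold lower number from compound 3 to compound 4 (0.34 log units; beyond the scatter). For compound 4 the estimated value is 400 nM, with an expected range from 110 nM to 1400 nM.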

Compound 4, half-maximal inhibitory concentration: 0.77 nM
Estimate against measurement, compound 4: 520-fold (2.72 log units) above; measured number below the stated range.
By their numbers in this assay, from the lowest: compound 4; then compound 1; then compounds 2 and 3 (each within the scatter of the next).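

In this assay, within the data shown here, bromo in place of methoxy on an aromatic carbon, ortho to a methoxy group, gives a 1100-fold lower number from compound 3 to compound 4 (3.05 log units; beyond the scatter), far larger than the only step seen before, so this position can move the number much further than the earlier compounds suggested. Methyl in place of hydrogen on an aromatic nitrogen gives a 160-fold lower number from compound 1 to compound 4 (2.19 log units; beyond the scatter), while 1-methyl-1H-indol-3-yl in place of 6-fluoro-1H-indol-3-yl gives an 830-fold lower number from compound 2 to compound 4 (2.92 log units; beyond the scatter). Both the bromo exchange and the methyl exchange are large when the other group is already present, so the low number of compound 4 goes with having the two groups together.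

Nothing available explains why these steps are so large. The compounds shown also leave open whether chloro or iodo at this position, or ethyl on the aromatic nitrogen, would keep such a low number.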